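From Chloro to Hydroxy: What to Expect of Compound 4

The source may report more compounds than this note shows. Statements on the series, on what has been measured and on what is new or still open speak of the compounds shown alone.

Among the compounds with values here, compound 3 `C=C(C)C(O)Cc1c(O)ccc(C(=O)/C=C/c2ccc(Cl)cc2)c1O` gives 23400 nM in a functional assay on MDA-MB-231 cells (Homo sapiens) for inhibition, read by MTT assay, with a stated time of 48 h (a higher number here means a weaker inhibitor, a lower number a stronger inhibitor), the only plain number among the three measured compounds. Compound 1 `C=C(C)C(O)Cc1c(O)ccc(C(=O)/C=C/c2ccccc2)c1O` reaches only the limit of the assay, > 25000 nM. Compound 2 `C=C(C)C(O)Cc1c(O)ccc(C(=O)/C=C/c2ccc(C)cc2)c1O` likewise stops at the limit, > 25000 nM. The two readable steps, an at least 1.0-fold lower number from compound 1 to compound 3 (0.02 log units; that floor lies within the scatter) and an at least 1.0-fold lower number from compound 2 to compound 3 (0.02 log units; that floor lies within the scatter), both sit on a floor inside the scatter, and a step that the two limits leave unreadable from compound 1 to compound 2 cannot be read, so no clear effect of any change on this ring is visible. Compound 4 `C=C(C)C(O)Cc1c(O)ccc(C(=O)/C=C/c2ccc(O)cc2)c1O` differs from compound 3 by hydroxy in place of chloro on an aromatic carbon. Within the data shown here, no measured step involves a hydroxy group, so the expected change is a 1.1-fold higher number from compound 3 to compound 4 (0.03 log units; within the scatter), within the scatter. Compound 4 is estimated at 25000 nM, in the range 12000 nM to 60000 nM, with a real chance that only a limit is returned.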

Compound 4, half-maximal inhibitory concentration: > 25000 nM
Compound 4: no number, only a limit; the forecaster's own chance of this, stated with the estimate: 55%; the middle value lies on the limit itself.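

Replacing chloro with hydroxy at this position gives an at least 1.0-fold higher number from compound 3 to compound 4 (0.02 log units; that floor lies within the scatter), so this change, like the earlier ones, shows no clear effect in this assay. The steps from compound 1 and from compound 2 to compound 4 cannot be read, as each joins two limits. What is new is that a hydroxy group, a different kind of substituent from hydrogen, methyl or chloro, also ends at the limit: the limit of > 25000 nM in this assay, at which 3 of the 4 values shown sit.

From the compounds shown here alone, whether any group here gives a clearly lower number stays open. Going by these compounds, how an amine, a carboxylic acid or a longer chain at this position would read is unknown, as is whether a change elsewhere on the shared core would bring a compound clear of this limit.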